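Removing the 4-fluorophenyl group: effect on cytotoxicity

The source may report more compounds than this note shows. Statements on the series, on what has been measured and on what is new or still open speak of the compounds shown alone.

compound 1 `CC(C)Nc1nc2cc(-c3ccc(Br)cc3)sc2c(=O)[nH]1` — 13400 nM
compound 2 `CC(C)Nc1nc2cc(-c3ccc(F)cc3)sc2c(=O)[nH]1` — > 25000 nM

In an ADME assay on HepG2 cells (Homo sapiens) for cytotoxicity, read by MTT assay, with a stated time of 72 h (on this read-out higher numbers stand for lower toxicity in this test and lower numbers for higher toxicity in this test), compound 1 gives 13400 nM. For compound 2 the value > 25000 nM is a limit of the assay rather than a number, so compound 2 stands at the limit of > 25000 nM in this assay, at which 1 of the 2 values shown sits. Going by the values given here, the single measured step, an at least 1.8-fold higher number from compound 1 to compound 2 (0.27 log units; that floor lies within the scatter), runs up to that limit. Compound 3 `CC(C)Nc1nc2ccsc2c(=O)[nH]1` differs from compound 2 by hydrogen in place of 4-fluorophenyl on an aromatic carbon. Among the compounds with values here, no measured step mirrors this change, so the step that the limit leaves unreadable from compound 2 to compound 3 is expected to stay within the scatter. Compound 3 is therefore estimated at 30000 nM, between 12000 nM and 80000 nM.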

Compound 3, half-maximal cytotoxic concentration: 23900 nM
For compound 3 the middle estimate is 1.3-fold (0.10 log units) above the measured one, within the range that was stated.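

In this assay, hydrogen in place of the aryl group gives a 1.8-fold higher number from compound 1 to compound 3 (0.25 log units; within the scatter), so on this aromatic carbon next to the ring sulfur, losing the whole 4-bromophenyl group leaves the read-out within the scatter. The other step, an at least 1.0-fold lower number from compound 2 to compound 3 (0.01 log units; that floor lies within the scatter), rests on a limit and cannot be read as a size. Compound 2 stands at a limit: the limit of > 25000 nM in this assay, at which 1 of the 3 values shown sits.

Going by these compounds, what remains open is whether a different group on this carbon, such as an amine or a carboxylic acid, would shift the read-out beyond the scatter. On these data alone, the true value of compound 2 also remains open.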